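The source may report more compounds than this note shows. Statements on the series, on what has been measured and on what is new or still open speak of the compounds shown alone.

Compound 3 `Cc1nc(-c2cc3cc(OC(C)C)cc(C#N)c3[nH]2)sc1C(=O)O` stands highest of the three compounds measured in a functional assay on the whole organism (plasma, strain Sprague-Dawley) for inhibition, with Rattus norvegicus as the target, with a stated time of 1 h, at a dose of 10 mg/kg by the oral route (on this read-out higher numbers stand for more inhibition at the one dose given (going by the name of the read-out) and lower numbers for less inhibition), where compound 3 gives 19%. In this assay compound 1 `COc1cc([N+](=O)[O-])c2[nH]c(-c3nc(C)c(C(=O)O)s3)cc2c1` gives 4%, and compound 2 `Cc1nc(-c2cc3cc(CNS(C)(=O)=O)cc([N+](=O)[O-])c3[nH]2)sc1C(=O)O` gives 0%. The gap from compound 3 to compound 1 lies beyond the scatter, as does the gap from compound 3 to compound 2, so compound 3 gives the highest number of the three on this read-out.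

Compound 4 `Cc1nc(-c2cc3cc(OC(C)C)cc([N+](=O)[O-])c3[nH]2)sc1C(=O)O` differs from compound 3 in one place: nitro in place of cyano on an aromatic carbon. Among the measured compounds shown here, the only measured step, a number 4 percentage points lower from compound 1 to compound 2 (within the scatter), concerns a change at a different group and does not bear on the exchange of a cyano group for a nitro group. Compound 1 and compound 2 both carry a nitro group and give low numbers, while compound 3 carries a cyano group and gives the highest number; yet compound 3 also carries an isopropoxy group that compound 1 and compound 2 lack, so the two differences cannot be separated on these data.

For the measured compounds named here, with no step bearing directly on this change, a modest drop is expected: the step of a number 9 percentage points lower from compound 3 to compound 4 (within the scatter). Compound 4 is estimated to give 10% in this assay, with a range from 0% to 25%.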

Compound 4, a percentage reported as inhibition, in the whole organism at one dose (the size of the read-out at that dose, not a potency): 43%
Beside the measured number, compound 4's estimate is 33 percentage points below it; the measured number lies above the stated range.
By their numbers in this assay, from the lowest: compounds 2 and 1 (each within the scatter of the next); then compound 3; then compound 4.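

In this assay, among the compounds shown here, with the isopropoxy group held fixed on the shared core, the exchange of cyano for nitro on the aromatic carbon gives a number 24 percentage points higher from compound 3 to compound 4 (beyond the scatter) and so the nitro compound is the higher of this pair, a separation that the earlier compounds, which differed in two places, could not make. With the nitro group held fixed, isopropyl in place of methyl on the oxygen gives a number 39 percentage points higher from compound 1 to compound 4 (beyond the scatter) and isopropoxy in place of (methanesulfonamido)methyl gives a number 43 percentage points higher from compound 2 to compound 4 (beyond the scatter) and so the nitro group on its own does not tie the series to low numbers: among these three nitro compounds, the number depends on the group at the other place. No measurement on hand offers a reason for any of these steps.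

On these data alone, the advantage of nitro over cyano rests on a single pair, so it remains open whether it would hold with methoxy or another group in place of isopropoxy, or whether an amine or a fluorine atom at the same aromatic carbon would match the nitro group. Also open, as far as these compounds go, is whether a longer chain on the oxygen, such as butyl, would carry the number further than isopropyl does.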